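Methyl to chloro on a barely active pair

A few compounds are considered here, and "the series" means these few. Any claim that something is new, unique, unknown or untested is made for them only; others in the source may bear on it.

In a functional assay on SK-MEL-28 cells (Homo sapiens) for inhibition, read by MTT assay, with a stated time of 48 h (a higher number here means a weaker inhibitor, a lower number a stronger inhibitor), compound 1 `Cc1ccc(-c2nc3ccccn3c2Sc2ccccc2)cc1` gives > 100000 nM as a limit of the assay and not a number. Among the measured compounds shown here, compound 2 `Cc1ccc(-c2nc3ccc(C)cn3c2Sc2ccccc2)cc1` gives 95700 nM as the only actual number so far. For the measured compounds named here, the one measured step, an at least 1.0-fold lower number from compound 1 to compound 2 (0.01 log units; that floor lies within the scatter), is methyl in place of hydrogen on an aromatic carbon, and it has only a floor for its size. Compound 3 `Cc1ccc2nc(-c3ccc(Cl)cc3)c(Sc3ccccc3)n2c1` differs from compound 2 by chloro in place of methyl on an aromatic carbon, 4-methylphenyl to 4-chlorophenyl. Going by the values given here, no measured step covers this exchange, so no shift beyond the scatter is expected in this assay and the direction stays open. The expected change is a 1.4-fold lower number from compound 2 to compound 3 (0.14 log units; within the scatter) for this exchange. The estimate for compound 3 is 70000 nM with an expected range from 25000 nM to 100000 nM as the likely span.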

Compound 3, half-maximal inhibitory concentration: 81500 nM
Compound 3: middle estimate off by 1.2-fold (0.07 log units), on the low side; low and high end bracket the measured number.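

In this assay, the first exchange measured on the 4-methylphenyl ring, chloro in place of methyl, gives a 1.2-fold lower number from compound 2 to compound 3 (0.07 log units; within the scatter). At this aromatic carbon, para to a large group, the two groups therefore cannot be told apart, a finding that the earlier step, which concerned another place on the molecule, could not give. The comparison rests on two actual numbers, whereas the earlier step had only a floor for its size, and compound 1 gives a limit and not a number: the limit of > 100000 nM in this assay, at which 1 of the 3 values shown sits.

Whether any group at this position can move the number beyond the scatter stays open, as only methyl and chloro are shown there. As far as these compounds go, an amine, a carboxylic acid or a longer chain in place of the chloro would test this, and the phenyl on sulfur remains unexplored.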